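The source may hold more compounds than are shown below. What is called first, only, known or untested is meant among the compounds shown, and "the series" means these compounds.

Series notes. The shared core carries a methylpiperazinyl group, and the three measured compounds differ only in the side chain on the aromatic nitrogen. Compound 1 `CCOCCn1c(N2CCN(C)CC2)nc2ccccc21` gives 10 nM in a functional assay on ileum for inhibition of histamine H1 receptor (Cavia porcellus); a higher number here means a weaker inhibitor, a lower number a stronger inhibitor. Compound 2 `CCCCCCn1c(N2CCN(C)CC2)nc2ccccc21` gives 26 nM in this assay. Compound 3 `C#CCOCCn1c(N2CCN(C)CC2)nc2ccccc21` gives 12 nM in this assay. On these numbers compound 3 stands second highest of three: its nearest neighbour is compound 1, within the scatter, and its furthest is compound 2, beyond the scatter.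

Compound 4 `CCSCCn1c(N2CCN(C)CC2)nc2ccccc21` is not yet measured. It differs from compound 3 in one place: ethylsulfanyl in place of propargyloxy on a saturated chain carbon, two bonds along the chain from an aromatic nitrogen.

Bearing on this step are a 1.2-fold higher number from compound 1 to compound 3 (0.08 log units; within the scatter), which shows that changing the end of the oxygen-bearing chain from methyl to ethynyl leaves the number unchanged, and a 2.6-fold higher number from compound 1 to compound 2 (0.41 log units; beyond the scatter) together with a 2.2-fold lower number from compound 2 to compound 3 (0.34 log units; beyond the scatter), which show a modest rise in the number when the oxygen-containing chain is replaced by butyl. Ethylsulfanyl keeps one hydrogen-bond acceptor in the chain, as ethoxy and propargyloxy do, so the step is expected to stay within the scatter or rise only modestly, a 1.3-fold higher number from compound 3 to compound 4 (0.12 log units; within the scatter). Compound 4 is therefore estimated at 16 nM, with a range from 6 nM to 40 nM.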

Compound 4, half-maximal inhibitory concentration: 19 nM
Compound 4: the middle estimate sits 1.2-fold (0.07 log units) below what was measured, and the stated range covers the measured number.
By their numbers in this assay, from the lowest: compounds 1, 3, 4 and 2 (each within the scatter of the next, the first and the last beyond it).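

In this assay the 2-(ethylsulfanyl)ethyl chain cannot be separated from any of the three earlier chains: ethylsulfanyl in place of propargyloxy gives a 1.6-fold higher number from compound 3 to compound 4 (0.20 log units; within the scatter) and in place of ethoxy gives a 1.9-fold higher number from compound 1 to compound 4 (0.28 log units; within the scatter) while in place of butyl it gives a 1.4-fold lower number from compound 2 to compound 4 (0.14 log units; within the scatter) at the same place on the chain. Compound 1 and compound 2 stand apart beyond the scatter, yet compound 4 falls within the scatter of both, so this position accepts sulfur in the chain with no readable change, and the new compound neither sharpens nor removes the earlier gap between the ethoxy and butyl chains. No data given here account for any of these steps.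

On these data alone, whether the gap between compound 1 and compound 2 reflects the oxygen in the chain or something else remains open, since compound 4 sits within the scatter of both ends. Also open, as far as these compounds go, is how the position responds to a sulfone, a hydroxyl group, an amine or a longer ether chain on the same two-carbon link.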